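From 4-aminophenyl to 4-aminocyclohexyl in a cytotoxicity series

The compounds below may be only part of what the source reports. "The series", "measured", "known", "first", "only" and "open" are said of these compounds alone.

- compound 1 `N[C@H]1CC[C@H](Nc2c(C(=O)NCc3ccc(F)cc3)nc(N3CCCCS3(=O)=O)c3cccnc23)CC1`: > 10000 nM (a limit, not a number)
- compound 2 `Nc1cccc(Nc2c(C(=O)NCc3ccc(F)cc3)nc(Br)c3cccnc23)c1`: > 10000 nM (a limit, not a number)
- compound 3 `Nc1ccc(Nc2c(C(=O)NCc3ccc(F)cc3)nc(Br)c3cccnc23)cc1`: 7000 nM

Among the measured compounds shown here, in a functional assay on HCT-116 cells (Homo sapiens) for cytotoxicity, read by MTT assay, with a stated time of 72 h (a higher number here means a weaker inhibitor, a lower number a stronger inhibitor), compound 3 gives 7000 nM, the only true number so far. The other two values are limits of the assay, so they give no exact position.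

Going to compound 4 `N[C@H]1CC[C@H](Nc2c(C(=O)NCc3ccc(F)cc3)nc(Br)c3cccnc23)CC1` replaces the aromatic ring with a non-aromatic one: 4-aminocyclohexyl in place of 4-aminophenyl on a nitrogen on an aromatic ring, on a nitrogen on an aromatic ring.

One measured step changes the same place, and it is a swap of 3-aminophenyl for 4-aminophenyl: an at least 1.4-fold lower number from compound 2 to compound 3 (0.15 log units; that floor lies within the scatter). That step is small and stays within the scatter. The 4-aminocyclohexyl group also stands on compound 1, which differs elsewhere, and compound 1 reads > 10000 nM, which is a limit.

With so little evidence, only a small move is expected, a 1.2-fold lower number from compound 3 to compound 4 (0.07 log units; within the scatter), and nothing beyond the scatter. The estimate for compound 4 is 6000 nM, expected to lie between 1500 nM and 10000 nM in this assay, and a reading at the limit would be no surprise.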

Compound 4, half-maximal inhibitory concentration: 4000 nM
Beside the measured number, compound 4's estimate is 1.5-fold (0.18 log units) above it; the range from low to high includes it.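

In this assay, the change at this nitrogen gives a 1.8-fold lower number from compound 3 to compound 4 (0.24 log units; within the scatter), so a non-aromatic ring of carbon does as well here as the aromatic one. With 4-aminocyclohexyl on the nitrogen in both compounds, changing the group on the aromatic carbon gives an at least 2.5-fold lower number from compound 1 to compound 4 (0.39 log units; beyond the scatter), and changing the ring group while keeping bromine gives an at least 2.5-fold lower number from compound 2 to compound 4 (0.39 log units; beyond the scatter). These two steps beyond the scatter are only floors, not exact sizes, because each starts from a limit: the limit of > 10000 nM in this assay, at which 2 of the 4 values shown sit.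

Going by these compounds, it remains open whether bromine itself matters, or whether chlorine or a methyl group on that aromatic carbon would serve equally well. Also open, on these data alone, is whether the amine on the cyclohexyl ring matters, which a hydroxyl group in its place would test.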